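This account rests on a few compounds, and the source may have more. Where it says the series, first, only, none or still open, it means among the compounds named here.

The three compounds measured so far, with their affinities for the histamine receptor:

Compound 1, `CC(=O)c1ccc(OCCCN2CC[C@H](NS(=O)(=O)c3ccc(C#N)cc3)C2)cc1`: 2300 nM
Compound 2, `O=C(N[C@H]1CCN(CCCOc2ccc(C(=O)C3CC3)cc2)C1)c1csc(-c2cccnc2)n1`: 4000 nM
Compound 3, `N#Cc1ccc(S(=O)(=O)N[C@H]2CCN(CCCOc3ccc(C(=O)C4CC4)cc3)C2)cc1`: 1600 nM

In an assay on isolated protein for binding affinity to histamine H2 receptor (Homo sapiens) (on this read-out lower numbers stand for stronger inhibition and higher numbers for weaker inhibition), compound 3 gives 1600 nM, and compound 1 gives 2300 nM. These two share one core and differ only in one place: methyl in place of cyclopropyl on a carbonyl carbon. That change made a step of a 1.4-fold higher number from compound 3 to compound 1 (0.16 log units; within the scatter), so the two numbers cannot be told apart with confidence.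

Compound 2 has a different core; the difference between its core and that of compound 3 is not broken down here. Compound 2 gives 4000 nM, a higher number than that of compound 3.

Compound 4, `CC(=O)c1ccc(OCCCN2CC[C@H](NC(=O)c3csc(-c4cccnc4)n3)C2)cc1`, has not yet been measured. It is compound 2 with one change: methyl in place of cyclopropyl on a carbonyl carbon. Within the data shown here, this is the same change as the one from compound 3 to compound 1, at the same place on the carbonyl carbon, so the earlier step is the only guide available.

Because the earlier step of a 1.4-fold higher number from compound 3 to compound 1 (0.16 log units; within the scatter) was small, the step from compound 2 to compound 4 in this assay is expected to be about a 1.4-fold higher number from compound 2 to compound 4 (0.14 log units; within the scatter), with the different core of compound 2 adding some uncertainty. Compound 4 is therefore estimated to give 5500 nM in this assay, with a likely range from 2500 nM to 12000 nM.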

Compound 4, inhibition constant: 6200 nM
Beside the measured number, compound 4's estimate is 1.1-fold (0.05 log units) below it; low and high end bracket the measured number.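

In this assay, putting methyl in place of cyclopropyl on the carbonyl carbon gives a 1.6-fold higher number from compound 2 to compound 4 (0.19 log units; within the scatter), and this step can be set beside the one seen for the same change on the other core: the same change on two cores in this assay, a 1.4-fold higher number (0.16 log units; within the scatter) from compound 3 to compound 1 and a 1.6-fold higher number (0.19 log units; within the scatter) from compound 2 to compound 4, 1.1-fold (0.03 log units) apart, within the scatter of two such steps. The change therefore behaves alike on the two cores, and in both pairs the numbers cannot be told apart with confidence, so here, the small effect of the change carries over from one core to the other. This does not show that methyl and cyclopropyl truly differ in this assay, since neither step stands clear of the scatter, and two pairs of compounds cannot show that the same would hold on every core in the series or explain why the steps agree.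

The compounds shown carry only methyl and cyclopropyl on this carbonyl carbon, so they leave open how an ethyl group, a longer chain such as butyl, a larger ring such as cyclohexyl or an amine at that place would fare in this assay. They also leave open whether the step stays this small on a third core, and whether a group at that place can move the number by more than the scatter.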